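The source may hold more compounds than are shown below. What is called first, only, known or untested is meant among the compounds shown, and "the series" means these compounds.

Measured compounds in this series:
compound 1 `Cn1c(COc2cccc(C(=O)O)c2)nc2ccc(Oc3cc(Cl)ccn3)cc21`, 11 ug/mL
compound 2 `Cn1c(COc2cccc(C(=O)O)c2)nc2ccc(Oc3ncccc3Cl)cc21`, 15 ug/mL
compound 3 `Cc1cccc(Oc2ccc3nc(COc4cccc(C(=O)O)c4)n(C)c3c2)n1`, 92 ug/mL

The read-out throughout is a physicochemical assay for solubility, read by HPLC, measured as thermodynamic solubility, with a stated time of 4 h, at pH 6.8; a lower number here means a less soluble compound, a higher number a more soluble compound. Compound 3 holds the highest number of the three, with a 6.1-fold higher number from compound 2 to compound 3 (0.79 log units; beyond the scatter) and an 8.4-fold higher number from compound 1 to compound 3 (0.92 log units; beyond the scatter), both beyond the scatter. Compounds 1 and 2 sit within the scatter of each other, a 1.4-fold higher number from compound 1 to compound 2 (0.13 log units; within the scatter), and that step is the only one so far that moves a substituent around the pyridine ring without changing what the substituent is.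

Compound 4 `Cc1cccnc1Oc1ccc2nc(COc3cccc(C(=O)O)c3)n(C)c2c1` is the next compound for this assay. It differs from compound 3 in one place: 3-methylpyridin-2-yl in place of 6-methylpyridin-2-yl on an oxygen on an aromatic ring. The change keeps the methyl and the pyridine nitrogen and moves only where the methyl sits.

Among the measured compounds shown here, no measured step changes the position of a methyl on this ring. The steps from compound 1 and compound 2 to compound 3 swap a chloro for a methyl and so do not bear directly on a positional move. The closest guide is the positional chloro move, which stayed within the scatter. The expected step is therefore a 1.4-fold lower number from compound 3 to compound 4 (0.15 log units; within the scatter), small and not clearly beyond the scatter, with a modest downward lean since compound 3 is the high point of the set. Compound 4 is estimated at 65 ug/mL, expected between 25 ug/mL and 180 ug/mL.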

Compound 4, solubility: 37 ug/mL
Beside the measured number, compound 4's estimate is 1.8-fold (0.24 log units) above it; the range from low to high includes it.
By their numbers in this assay, from the lowest: compounds 1 and 2 (each within the scatter of the next); then compound 4; then compound 3.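

In this assay, moving the methyl on the pyridine ring gives a 2.5-fold lower number from compound 3 to compound 4 (0.40 log units; beyond the scatter) and so counts as a real change, whereas the only earlier positional move, made with chloro, gave a 1.4-fold higher number from compound 1 to compound 2 (0.13 log units; within the scatter) and stayed within the scatter. Among the compounds shown here, the series also now holds a clean swap of substituent with no shift of place: methyl in place of chloro on an aromatic carbon gives a 2.5-fold higher number from compound 2 to compound 4 (0.39 log units; beyond the scatter) and separates the identity of the group from its location, which the earlier steps to compound 3 could not do, as they changed both at once. The step from the 4-chloropyridin-2-yl compound to the 3-methylpyridin-2-yl compound, a 3.4-fold higher number from compound 1 to compound 4 (0.53 log units; beyond the scatter), points the same way, and among the compounds shown both methyl compounds stand beyond the scatter of both chloro compounds.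

Still open, from the compounds shown here alone, is how a methoxy, a fluoro or an amine on the same pyridine ring would read in this assay, and whether the order seen with methyl would hold for any of them. No measurement shown here bears on why the place of the methyl or the swap from chloro moves the number.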